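Amine-to-amide swap on the outer ring of the series

This account rests on a few compounds, and the source may have more. Where it says the series, first, only, none or still open, it means among the compounds named here.

Measured so far:
compound 1, `CCNC(=O)c1noc(-c2cc(C(C)C)c(O)cc2O)c1-c1cc(COCC(=O)O)no1` — "not determined" (no result reported) in a functional assay on HCT-116 cells (Homo sapiens) for inhibition; on this read-out higher numbers stand for weaker inhibition and lower numbers for stronger inhibition
compound 2, `CCNC(=O)c1noc(-c2cc(C(C)C)c(O)cc2O)c1-c1cc(CNC)no1` — 164 nM
compound 3, `CCNCc1cc(-c2c(C(=O)NCC)noc2-c2cc(C(C)C)c(O)cc2O)on1` — 45 nM

Compound 3 holds the lowest of the two numbers available in this assay. Within the data shown here, its nearest neighbour is compound 2, and the single step within the set, a 3.6-fold lower number from compound 2 to compound 3 (0.56 log units; beyond the scatter), is the whole of the measured ground: methyl in place of hydrogen on a saturated chain carbon bound to an amine nitrogen. Compound 1 gives no number and adds nothing to the comparison.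

Compound 4, `CCNC(=O)c1noc(-c2cc(C(C)C)c(O)cc2O)c1-c1cc(C(=O)NC)no1`, departs from compound 3 by methylcarbamoyl in place of (ethylamino)methyl on an aromatic carbon. Among the measured compounds shown here, no measured step covers this kind of change: the one step seen alters only the chain on the amine nitrogen, whereas here the amine carbon itself is replaced by a carbonyl and the ethyl by a methyl. What the data do show is that the amine-bearing chain in compound 3 sits at the strong end of the set, so its removal is taken as a risk rather than a gain.

Compound 4 is therefore expected to return a higher number, with the step estimated at a 3.3-fold higher number from compound 3 to compound 4 (0.52 log units; beyond the scatter). The estimate for compound 4 in this assay is 150 nM, with a range from 40 nM to 600 nM.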

Compound 4, half-maximal inhibitory concentration: 124 nM
Estimate against measurement, compound 4: 1.2-fold (0.08 log units) above, within the range that was stated.
By their numbers in this assay, from the lowest: compound 3; then compounds 4 and 2 (each within the scatter of the next).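

Swapping (ethylamino)methyl for methylcarbamoyl on this aromatic carbon, next to the ring nitrogen, gives a 2.8-fold higher number from compound 3 to compound 4 (0.44 log units; beyond the scatter) in this assay, so the ethyl amine keeps its edge over the amide. Against the (methylamino)methyl group, the same methylcarbamoyl gives a 1.3-fold lower number from compound 2 to compound 4 (0.12 log units; within the scatter), which places the methyl amide and the methyl amine level on this read-out and shows that a basic-free carbonyl link at this position need not cost anything relative to compound 2. Nothing available on these compounds accounts for either step.

The step to compound 4 changes the link and shortens the chain at once, so the ethylcarbamoyl group is the open case: it would show whether the amide follows the same ethyl-over-methyl direction seen between the two amines. Also open, on these data alone, are a longer chain on the amine, such as (propylamino)methyl, and a carboxylic acid placed directly on this aromatic carbon.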